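This account rests on a few compounds, and the source may have more. Where it says the series, first, only, none or still open, it means among the compounds named here.

Measured so far in an assay on HEK293 cells for inhibition of Voltage-dependent T-type calcium channel subunit alpha-1G (Homo sapiens), read by patch clamp; a lower number here means a stronger inhibitor, a higher number a weaker inhibitor:

compound 1 `CCCc1nc(-c2ccccc2)c(CNCCN2CCN(c3ccccc3Cl)CC2)o1`: 4370 nM
compound 2 `CCCc1nc(-c2ccccc2)c(CNCCCN2CCN(c3ccccc3F)CC2)o1`: 16100 nM

Compound 2 gives the highest of the two numbers; the nearest is compound 1, whose value is lower by an amount that lies beyond the usual scatter. For the measured compounds named here, no single-change step connects these two, as they differ in more than one place, so their values are noted side by side without drawing a step from them.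

Compound 3 `CCCc1nc(-c2ccccc2)c(CNCCCN2CCN(c3ccc(C)cc3)CC2)o1` is the next member of the series, to be measured in this assay. The change from compound 2 is 4-methylphenyl in place of 2-fluorophenyl on an amine nitrogen in a ring. Going by the values given here, nothing measured isolates this change, so there is no direct precedent for its size or direction.

The expectation is for a step of modest size, within or close to the scatter, leaning slightly towards a lower number, as expressed by a 1.5-fold lower number from compound 2 to compound 3 (0.17 log units; within the scatter). Among the compounds with values here, compound 3 is estimated at 11000 nM, with a range from 3000 nM to 40000 nM to cover the uncertainty of a change that has no measured counterpart.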

Compound 3, half-maximal inhibitory concentration: 130000 nM
For compound 3 the middle estimate is 12-fold (1.07 log units) below the measured one; measured number above the stated range.
By their numbers in this assay, from the lowest: compound 1; then compound 2; then compound 3.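

Within this assay, the move from 2-fluorophenyl to 4-methylphenyl on the amine nitrogen in the ring is the first single-change step in the series, and it gives an 8.1-fold higher number from compound 2 to compound 3 (0.91 log units; beyond the scatter), which lies beyond the scatter. This place is therefore sensitive to the choice of substituted phenyl, even though the two groups match in heavy-atom count, each carry one six-membered aromatic ring of carbon only, and have no hydrogen-bond donors or acceptors. Compound 3 now has the highest number of the three, 130000 nM, while compound 1 differs from both other compounds in more than one place and so adds no clean comparison to this step.

The compounds shown leave open whether the higher number follows from losing the 2-fluorophenyl or from bringing in the 4-methylphenyl, a question that an unsubstituted phenyl or a methoxy-bearing phenyl on the same longer chain would help to separate. Nothing available bears on the reason for the size of this step.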